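The source may report more compounds than this note shows. Statements on the series, on what has been measured and on what is new or still open speak of the compounds shown alone.

Working notes on the series.

Three compounds have numbers in a functional assay on CHO cells for antagonist activity at C-C chemokine receptor type 4 (Homo sapiens), read by GTPgammaS binding; on this read-out lower numbers stand for stronger inhibition and higher numbers for weaker inhibition. Compound 1 `CC(=O)NCc1cccc(Cn2nc(NS(=O)(=O)c3ccc(Cl)s3)c3c(Cl)cccc32)c1` gives 31.6 nM. Within the data shown here, compound 2 `CC(=O)NCc1cccc(Cn2nc(NS(=O)(=O)c3ccc(Cl)s3)c3c(F)cccc32)c1` gives 79.4 nM; the step of a 2.5-fold higher number from compound 1 to compound 2 (0.40 log units; beyond the scatter) is the only single-point step measured so far. Compound 3 `COc1cccc2c1c(NS(=O)(=O)c1ccc(Cl)s1)nn2Cc1cccc(CNC(=O)C2CCCO2)c1` gives 39.8 nM, which lies within the scatter of both compound 1 and compound 2, so no order among the three can be stated from this pair of gaps.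

Compound 4 `COc1cccc2c1c(NS(=O)(=O)c1ccc(Cl)s1)nn2Cc1cccc(CNC2COC2)c1` is not yet measured. It differs from compound 3 by oxetan-3-yl in place of (oxolan-2-yl)carbonyl on an amine nitrogen. Among the measured compounds shown here, the one measured step, from compound 1 to compound 2, concerns a different change on a different part of the shared core and does not bear on this amide-to-amine exchange; no measured pair in this assay isolates the change at the amine nitrogen. The expectation for compound 4 therefore rests on compound 3 alone, with wide bounds, and a step of a 1.6-fold higher number from compound 3 to compound 4 (0.20 log units; within the scatter) is estimated. Compound 4 is expected to give about 63 nM, in the range 20 nM to 200 nM.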

Compound 4, half-maximal inhibitory concentration: 251 nM
The estimate for compound 4 lay 4.0-fold (0.60 log units) below the measured number; the measured number lies above the stated range.
By their numbers in this assay, from the lowest: compounds 1, 3 and 2 (each within the scatter of the next, the first and the last beyond it); then compound 4.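

In this assay, the exchange at the amine nitrogen gives a 6.3-fold higher number from compound 3 to compound 4 (0.80 log units; beyond the scatter), the first step measured at this position, and it lies beyond the scatter, so the group carried on this nitrogen matters to the read-out. The change is not a single one: the group that leaves has more heavy atoms, a five-membered rather than a four-membered ring, and a double bond outside aromatic rings, which the group that enters lacks, so this one step cannot assign the loss to any one of these features. Nothing available here bears on the cause of this step.

Whether the carbonyl or the ring accounts for the step stays open; a pairing of compound 3 with (oxetan-3-yl)carbonyl on the same nitrogen would separate the two. Also open, from the compounds shown here alone, is how an oxolan-3-yl group or a plain acetyl group on this nitrogen would read.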